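The source may hold more compounds than are shown below. What is called first, only, known or untested is meant among the compounds shown, and "the series" means these compounds.

Two compounds have numbers in a functional assay on KBVIN cells (Homo sapiens) for cytotoxicity, read by sulforhodamine B assay, with a stated time of 3 days (on this read-out lower numbers stand for an effect already at smaller amounts and higher numbers for an effect only at larger amounts of compound), so far. There compound 1 `COC(=O)c1c(C)coc1-c1ccc2c(c1OC)CCCC2(C)C` gives 52.1 uM and compound 2 `Cc1coc(-c2ccc3c(c2O)CCCC3(C)C)c1C(=O)O` gives 4.7 uM as the lower number of the two, a gap beyond the usual scatter. Compound 3 `COc1c(-c2occ(C)c2C(=O)O)ccc2c1CCCC2(C)C` is still unmeasured. Compared with compound 2 it carries a single change (methyl in place of hydrogen on an oxygen on an aromatic ring) that reads as methyl in place of hydrogen on an oxygen on an aromatic ring, or hydroxy to methoxy. For the measured compounds named here, no measured pair shows this change alone. Compound 3 does share the methoxy of compound 1 (52.1 uM) so a higher number is expected, though probably not one as high. Expected in this assay is a 3.4-fold higher number from compound 2 to compound 3 (0.53 log units; beyond the scatter) as a move toward a higher number and beyond the scatter. Compound 3 is estimated at 16 uM with 6 uM to 45 uM as the expected range.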

Compound 3, concentration for half-maximal effect: 47.8 uM
Estimate against measurement, compound 3: 3.0-fold (0.48 log units) below; the measured number lies above the stated range.
By their numbers in this assay, from the lowest: compound 2; then compounds 3 and 1 (each within the scatter of the next).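

In this assay, methyl in place of hydrogen on an oxygen on an aromatic ring now stands as a single change, and it gives a 10-fold higher number from compound 2 to compound 3 (1.01 log units; beyond the scatter), so this one position moves the number well beyond the scatter. The other single change, hydrogen in place of methyl on an oxygen next to a carbonyl group, gives only a 1.1-fold lower number from compound 1 to compound 3 (0.04 log units; within the scatter), so with the methoxy present, the carboxylic acid and the methyl ester read alike. Nothing shown here speaks to what lies behind these two steps.

The compounds shown leave open whether hydroxy to methoxy gives a step of similar size when a methyl ester stands in place of the carboxylic acid. They also leave open how an ethoxy or an amine would read in place of the hydroxy.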